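Adding a methyl to compound 2: what inhibition to expect

A few compounds are considered here, and "the series" means these few. Any claim that something is new, unique, unknown or untested is made for them only; others in the source may bear on it.

Of the compounds shown here, two have been measured in a functional assay for inhibition, tested at 100 uM; a lower number here means less inhibition, a higher number more inhibition at the concentration tested (going by the name of the read-out). Compound 1, `Cc1ccc(S(=O)(=O)c2c[nH]cc2S(=O)(=O)CC2=NCCO2)cc1`, gives 78.5% in this assay. Compound 2, `O=S(=O)(CC1=NCCS1)c1c[nH]cc1S(=O)(=O)c1ccccc1`, gives 34.6% in this assay, the lower of the two numbers by a margin that lies beyond the scatter of repeat measurements. The two compounds differ in more than one place, so no single structural change can be credited with the gap between them.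

Compound 3, `Cc1ccc(S(=O)(=O)c2c[nH]cc2S(=O)(=O)CC2=NCCS2)cc1`, is not yet measured. It differs from compound 2 in one place: methyl in place of hydrogen on an aromatic carbon. Compound 1 also carries this methyl group, but its higher number cannot be tied to the methyl alone, since compound 1 and compound 3 still differ elsewhere. A modest rise in inhibition is expected, and compound 3 is estimated to give 55%, somewhere between 30% and 80%. This expected step from compound 2 reads a number 20.4 percentage points higher from compound 2 to compound 3 (beyond the scatter).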

Compound 3, a percentage reported as inhibition, at one concentration (the size of the read-out at that concentration, not a potency): 23.7%
Compound 3: middle estimate off by 31.3 percentage points, on the high side; measured number outside the range, below it.
By their numbers in this assay, from the lowest: compound 3; then compound 2; then compound 1.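

In this assay, the change from phenyl to 4-methylphenyl gives a number 10.9 percentage points lower from compound 2 to compound 3 (beyond the scatter), so a methyl at this place, para to a large group, does not raise inhibition when the sulfur-bearing five-membered ring is present. Compound 1 and compound 3 share the 4-methylphenyl and differ only in that five-membered non-aromatic ring, with oxygen in compound 1 and sulfur in compound 3, and this swap reads a number 54.8 percentage points lower from compound 1 to compound 3 (beyond the scatter), a large step against the modest one for the methyl. Nothing measured here bears on why either step has its size.

The compounds shown leave open whether the methyl step would look the same with the oxygen-bearing ring in place of the sulfur-bearing one. They also leave open how a different group at the same place, such as a methoxy or a chlorine, would read.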